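This account rests on a few compounds, and the source may have more. Where it says the series, first, only, none or still open, it means among the compounds named here.

Compound 1 `CCOC(=O)C1=C(C)N/C(=C/c2cc(C)n(-c3ccc(F)cc3F)c2C)C1=O` gives 77 mL.min-1.g-1 in an ADME assay on microsomes from liver (Mus musculus) for metabolic stability, read by LC-MS, tested at 1 uM; a higher number here means faster removal of the compound, a lower number slower removal.
Compound 2 `CCOC(=O)C1=C(C)N/C(=C/c2cc(C)n(-c3cc(OC)c(OC)c(OO)c3)c2C)C1=O` gives 63 mL.min-1.g-1 in this assay.

Of the two numbers, compound 1 has the higher one, but the gap to compound 2 falls within the scatter, so the two compounds cannot be told apart in this assay. Compound 3 `CCOC(=O)C1=C(C)N/C(=C/c2cc(C)n(-c3ccncc3)c2C)C1=O` is not yet measured. It differs from compound 1 in one place: pyridin-4-yl in place of 2,4-difluorophenyl on an aromatic nitrogen. Within the data shown here, no measured pair shows the effect of such a change, so compound 3 is expected to stay close to compound 1, with a step of a 1.2-fold lower number from compound 1 to compound 3 (0.07 log units; within the scatter) judged as none beyond the scatter. Compound 3 is thus estimated at 65 mL.min-1.g-1, between 30 mL.min-1.g-1 and 130 mL.min-1.g-1.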

Compound 3, intrinsic clearance in microsomes: 61 mL.min-1.g-1
Compound 3: the middle estimate sits 1.1-fold (0.03 log units) above what was measured; the range from low to high includes it.
By their numbers in this assay, from the lowest: compounds 3, 2 and 1 (each within the scatter of the next).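

In this assay, among these compounds, pyridin-4-yl in place of 2,4-difluorophenyl on the aromatic nitrogen gives a 1.3-fold lower number from compound 1 to compound 3 (0.10 log units; within the scatter) and is the first one-place change seen at this position. Compound 1 and compound 3 cannot be told apart, although a carbon-only ring with two fluorines gives way to a ring with one nitrogen. No measurement at hand accounts for this. Going by these compounds, whether a chain ending in an amine or a carboxylic acid on this nitrogen would move the number beyond the scatter stays open. So does the effect of replacing the ethyl ester with an amide.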